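The compounds below may be only part of what the source reports. "The series", "measured", "known", "first", "only" and "open" are said of these compounds alone.

Measured in a functional assay on RPMI-8226 cells (Homo sapiens) for inhibition, read by sulforhodamine B assay, with a stated time of 48 h (on this read-out higher numbers stand for weaker inhibition and lower numbers for stronger inhibition), so far:
compound 1 `COc1cc(-c2nn(-c3cccc(NC(=O)Nc4cc(C(F)(F)F)cc(C(F)(F)F)c4)c3)cc2-c2ccncc2)ccc1Cl`, 310 nM
compound 2 `COc1cc(-c2nn(-c3cccc(NC(=O)c4cccc(C(F)(F)F)c4)c3)cc2-c2ccncc2)ccc1Cl`, 1570 nM
compound 3 `O=C(Nc1cccc(-n2cc(-c3ccncc3)c(-c3ccc(Cl)c(O)c3)n2)c1)Nc1ccc(Cl)c(Cl)c1`, 1030 nM

Compound 2 gives the highest number of the three in this assay; the gap to compound 3 is within the scatter, the gap to compound 1 is beyond it. Compound 4 `COc1cc(-c2nn(-c3cccc(NC(=O)Nc4cccc(C(F)(F)F)c4)c3)cc2-c2ccncc2)ccc1Cl` is not yet measured. It differs from compound 2 by (3-(trifluoromethyl)phenyl)amino in place of 3-(trifluoromethyl)phenyl on a carbonyl carbon, and compound 1 carries the same carbonyl-flanking arrangement. Among the measured compounds shown here, no measured pair isolates this change, so the size of the step is uncertain. Because compound 1 stands at 310 nM, a move to a lower number is expected, of about a 2.9-fold lower number from compound 2 to compound 4 (0.46 log units; beyond the scatter) in this assay. Compound 4 is expected at roughly 550 nM, between 200 nM and 1500 nM.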

Compound 4, half-maximal inhibitory concentration: 340 nM
Estimate against measurement, compound 4: 1.6-fold (0.21 log units) above; the range from low to high includes it.
By their numbers in this assay, from the lowest: compounds 1 and 4 (each within the scatter of the next); then compounds 3 and 2 (each within the scatter of the next).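

In this assay, among the compounds shown here, the change to (3-(trifluoromethyl)phenyl)amino from 3-(trifluoromethyl)phenyl on a carbonyl carbon gives a step beyond the scatter (a 4.6-fold lower number from compound 2 to compound 4 (0.66 log units; beyond the scatter)), the first single-place reading of this position. Hydrogen in place of trifluoromethyl on an aromatic carbon stays within the scatter (a 1.1-fold higher number from compound 1 to compound 4 (0.04 log units; within the scatter)), so in this pair the extra trifluoromethyl of compound 1 brings no readable gain. No measured data on hand explain either step.

The compounds shown leave open whether the amino nitrogen itself is required on the carbonyl carbon. An oxygen or a methylene at that place would test this.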